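The source may hold more compounds than are shown below. What is called first, only, known or untested is meant among the compounds shown, and "the series" means these compounds.

Of the compounds shown here, three have been tested in a toxicity assay on NIH3T3 cells (Mus musculus) for cytotoxicity, read by resazurin assay; on this read-out lower numbers stand for an effect already at smaller amounts and higher numbers for an effect only at larger amounts of compound. Compound 1 `Cc1cccc(-c2cccc(NCc3cncn3Cc3ccccc3)c2)c1C` gives only a limit there, > 1000 nM. Compound 2 `Cc1ccccc1-c1cccc(NCc2cncn2Cc2ccccc2)c1` also gives only a limit in this assay, > 1000 nM. Compound 3 `Cc1ccccc1-c1cc(NCc2cncn2Cc2ccc(-c3ccccc3)cc2)ccc1-c1nc2ccccc2s1` likewise gives only a limit in this assay, > 1000 nM. Compound 2 and compound 1 differ by methyl in place of hydrogen on an aromatic carbon, and the two limits leave the step that the two limits leave unreadable from compound 2 to compound 1 unreadable. How the core of compound 3 differs from the core of compound 2 is not broken down here. Compound 4 `Cc1cccc(-c2cc(NCc3cncn3Cc3ccc(-c4ccccc4)cc3)ccc2-c2nc3ccccc3s2)c1C` has not yet been measured; it differs from compound 3 by methyl in place of hydrogen on an aromatic carbon, the same kind of change as from compound 2 to compound 1. Because (the limit of > 1000 nM in this assay, at which 3 of the 3 values shown sit), the step that the limit leaves unreadable from compound 3 to compound 4 is expected to be small. Compound 4 is therefore expected to give about 3000 nM in this assay, most likely again only a limit.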

Compound 4, half-maximal effective concentration: > 1000 nM
Compound 4: only a limit was reported; the forecaster's own chance of this, stated with the estimate: 85%; the middle value does not contradict the limit.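

No step can be read between compound 3 and compound 4, as each gives only a limit in this assay. The compounds shown leave open where any of them actually reaches its half-maximal effect, and whether the added methyl shifts that point.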